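Methyl on the Hydroxy Group: Expected Effect in Cells

The compounds below may be only part of what the source reports. "The series", "measured", "known", "first", "only" and "open" are said of these compounds alone.

Measured in a functional assay on UACC-257 cells (Homo sapiens) for inhibition, read by sulforhodamine B assay, with a stated time of 48 h, tested at 0.01 uM; on this read-out lower numbers stand for a stronger effect and higher numbers for a weaker effect at the one concentration tested:
Compound 1 `O=C(Nc1cccc(-n2cc(-c3ccncc3)c(-c3cc(O)cc(Cl)c3)n2)c1)Nc1ccc(Cl)c(C(F)(F)F)c1` gives 90%
Compound 2 `O=C(Nc1cccc(-n2cc(-c3ccncc3)c(-c3cc(O)cc(Cl)c3)n2)c1)Nc1ccc(Cl)c(Cl)c1` gives 96%
Compound 3 `COc1cc(Cl)cc(-c2nn(-c3cccc(NC(=O)Nc4cc(C(F)(F)F)cc(C(F)(F)F)c4)c3)cc2-c2ccncc2)c1` gives 96%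

Compound 2 stands level with compound 3 at the digits shown, the two together the highest of the three numbers, and the only measured single change, a number 6 percentage points higher from compound 1 to compound 2 (within the scatter), lay within the scatter. Compound 4 `COc1cc(Cl)cc(-c2nn(-c3cccc(NC(=O)Nc4ccc(Cl)c(Cl)c4)c3)cc2-c2ccncc2)c1` differs from compound 2 in one place: methyl in place of hydrogen on an oxygen on an aromatic ring. Among the measured compounds shown here, no measured step tests this hydrogen-to-methyl change directly. Compound 3, which already carries the methoxy group with a different urea partner, gives 96%, level with compound 2. For this assay the expected step is therefore none beyond the scatter, a number 1 percentage points lower from compound 2 to compound 4 (within the scatter). Compound 4 is estimated at 95%, with a range from 85% to 100%.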

Compound 4, a percentage reported as activity, at one concentration (the size of the read-out at that concentration, not a potency): 96%
Compound 4: middle estimate off by 1 percentage points, on the low side; the measured number falls inside the stated range.
By their numbers in this assay, from the lowest: compounds 1, 2, 3 and 4 (each within the scatter of the next).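

In this assay, replacing the hydroxy group with methoxy while keeping the urea partner fixed gives no change at the digits printed from compound 2 to compound 4 (within the scatter). This direct comparison shows that, at this one concentration, adding methyl on this oxygen does not separate the pair, whereas the earlier comparison with compound 3 also involved a different urea partner. No measurement shown gives a reason for this outcome. Still open, from the compounds shown here alone, is whether a longer chain on this oxygen, such as ethyl or propyl, would shift the read-out. An amine in place of the hydroxy group also remains untested among the compounds shown.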